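A few compounds are considered here, and "the series" means these few. Any claim that something is new, unique, unknown or untested is made for them only; others in the source may bear on it.

Measured in a functional assay on NCI-H1975 cells (Homo sapiens) for inhibition, read by MTT assay, with a stated time of 72 h; on this read-out higher numbers stand for weaker inhibition and lower numbers for stronger inhibition:
compound 1, `C=CC(=O)Nc1cccc(NC(=O)CSc2nc(Nc3cccc(F)c3)c3ccccc3n2)c1`, gives 2030 nM
compound 2, `C=CC(=O)Nc1cccc(NC(=O)CSc2nc(Nc3cccc(OC)c3)c3ccccc3n2)c1`, gives 7940 nM

Among the measured compounds shown here, compound 2 has the highest number of the two; the only measured step in this set is a 3.9-fold higher number from compound 1 to compound 2 (0.59 log units; beyond the scatter). Compound 3, `C=CC(=O)Nc1cccc(NC(=O)CSc2nc(Nc3ccc(Cl)cc3Cl)c3ccccc3n2)c1`, differs from compound 2 by 2,4-dichlorophenyl in place of 3-methoxyphenyl on a nitrogen on an aromatic ring. For the measured compounds named here, no measured step swaps a methoxy-bearing ring for a chlorine-bearing one, so only the step from compound 1 to compound 2 bears on it: going from a fluorine-bearing ring to the methoxy-bearing ring raised the number modestly. Moving back to a halogen-bearing ring, here 2,4-dichlorophenyl, is expected to lower the number by about a 2.6-fold lower number from compound 2 to compound 3 (0.42 log units; beyond the scatter). Compound 3 is therefore estimated at 3000 nM, within a range from 800 nM to 12000 nM.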

Compound 3, half-maximal inhibitory concentration: 5990 nM
Compound 3: middle estimate off by 2.0-fold (0.30 log units), on the low side; the range from low to high includes it.
By their numbers in this assay, from the lowest: compound 1; then compounds 3 and 2 (each within the scatter of the next).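

In this assay, placing 2,4-dichlorophenyl where 3-methoxyphenyl stood on this nitrogen gives a difference within the scatter (a 1.3-fold lower number from compound 2 to compound 3 (0.12 log units; within the scatter)). A halogen-bearing ring therefore does not by itself bring the number down to that of compound 1, which stays the lowest of the three (a 3.0-fold higher number from compound 1 to compound 3 (0.47 log units; beyond the scatter)). Nothing available explains these differences. Still open, from the compounds shown here alone, is how a ring with a single chlorine would read, which would help separate the kind of halogen from the number of halogens. Also open, going by these compounds, is how a nitrile or an amine on this ring would compare.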